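A few compounds are considered here, and "the series" means these few. Any claim that something is new, unique, unknown or untested is made for them only; others in the source may bear on it.

Measured compounds and their values:

Compound 1, `FC(F)(F)c1cccc(-c2nc3cnc(Nc4ccccn4)cc3[nH]2)c1`, gives 47% in an ADME assay on microsomes from liver (Mus musculus) for metabolic stability, read by LC-MS, with a stated time of 30 min, tested at 0.1 uM; on this read-out higher numbers stand for a more stable compound and lower numbers for a less stable compound.
Compound 2, `COc1cccnc1Nc1cc2[nH]c(-c3cccc(C(F)(F)F)c3)nc2cn1`, gives 80% in this assay.

Compound 2 stands highest of the two numbers measured; its nearest neighbour is compound 1, and the step of a number 33 percentage points higher from compound 1 to compound 2 (beyond the scatter) lies beyond the scatter. Compound 3, `COc1ccnc(Nc2cc3[nH]c(-c4cccc(C(F)(F)F)c4)nc3cn2)c1`, has not yet been measured. It differs from compound 2 in one place: 4-methoxypyridin-2-yl in place of 3-methoxypyridin-2-yl on a nitrogen on an aromatic ring. For the measured compounds named here, no measured step concerns the same rearrangement, so the one step on record only indirectly bears on it. From the compounds shown here alone, that step, a number 33 percentage points higher from compound 1 to compound 2 (beyond the scatter), shows that the presence of the methoxy group makes a large difference; what its position on the pyridine ring does is unknown. Compound 2 is likely to remain the better reference, but with the group kept and only moved, a modest fall or no change beyond the scatter is expected. He estimates the step of a number 15 percentage points lower from compound 2 to compound 3 (beyond the scatter), and for compound 3 he expects 65%, within the range 40% to 85%.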

Compound 3, percent of the compound remaining: 62%
Beside the measured number, compound 3's estimate is 3 percentage points above it; measured number inside the range.
By their numbers in this assay, from the lowest: compound 1; then compound 3; then compound 2.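

In this assay, moving the methoxy group on the pyridine ring gives a number a number 18 percentage points lower from compound 2 to compound 3 (beyond the scatter) and so shows that its position counts, and that the gain seen earlier did not come from the mere presence of the group. The 4-methoxypyridin-2-yl group still retains part of that gain, with a number 15 percentage points higher from compound 1 to compound 3 (beyond the scatter) against the larger a number 33 percentage points higher from compound 1 to compound 2 (beyond the scatter) for the 3-methoxypyridin-2-yl group. No measurement on hand explains why the two positions differ.

The compounds shown leave open how the remaining places on the pyridine ring behave. They also leave open whether the 3-methoxypyridin-2-yl result would hold with an ethoxy group, a fluorine atom or an amine in place of the methoxy group.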